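Flavone ethers with amine side chains: cytotoxicity notes

The source may report more compounds than this note shows. Statements on the series, on what has been measured and on what is new or still open speak of the compounds shown alone.

Measured so far:
compound 1 `CCN(CC)CCCOc1c(O)cc(O)c2c(=O)cc(-c3ccccc3)oc12` — > 100000 nM
compound 2 `CN1CCN(CCCOc2c(O)cc(O)c3c(=O)cc(-c4ccccc4)oc23)CC1` — > 100000 nM
compound 3 `COc1c(OCCCN2CCN(C)CC2)cc(O)c2c(=O)cc(-c3ccccc3)oc12` — 9900 nM

In a functional assay on A549 cells (Homo sapiens) for cytotoxicity, read by MTT assay, with a stated time of 48 h (a higher number here means a weaker inhibitor, a lower number a stronger inhibitor), compound 1 gives only a limit, > 100000 nM. Compound 2 likewise gives only a limit in this assay, > 100000 nM. Among the compounds with values here, compound 3 is the one compound with a number in this assay, 9900 nM. The difference between the core of compound 3 and the core of compound 2 is not broken down here.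

The change from compound 2 to compound 1 is diethylamino in place of 4-methylpiperazin-1-yl on a saturated chain carbon, three bonds along the chain from an oxygen on an aromatic ring. Its step, a step that the two limits leave unreadable from compound 2 to compound 1, cannot be read because both values sit at the limit of > 100000 nM in this assay, at which 2 of the 3 values shown sit.

Compound 4 `CCN(CC)CCCOc1cc(O)c2c(=O)cc(-c3ccccc3)oc2c1OC` is not yet measured. It differs from compound 3 by diethylamino in place of 4-methylpiperazin-1-yl on a saturated chain carbon, three bonds along the chain from an oxygen on an aromatic ring, the same change as that from compound 2 to compound 1, at the same place. Since that earlier step is unreadable, the expectation for compound 4 rests on compound 3 alone, whose value is 9900 nM, and the step is expected to be small: a 1.2-fold higher number from compound 3 to compound 4 (0.08 log units; within the scatter). Compound 4 is thus estimated at 12000 nM, with a range from 4000 nM to 60000 nM.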

Compound 4, half-maximal inhibitory concentration: 1830 nM
Compound 4: the middle estimate sits 6.6-fold (0.82 log units) above what was measured, and the stated range ends above it.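

In this assay, putting diethylamino in place of 4-methylpiperazin-1-yl gives a 5.4-fold lower number from compound 3 to compound 4 (0.73 log units; beyond the scatter), so on this core the change can be read and lies beyond the scatter. Compound 1 and compound 2 each give only a limit, so the same change on their core cannot be read: the limit of > 100000 nM in this assay, at which 2 of the 4 values shown sit. Whether the step carries from one core to the other is therefore not shown, since it is seen on one core only and nothing here fixes its size or direction on the other.

Open, as far as these compounds go, is whether the step extends to other amines or chain lengths on the core of compound 4, for example morpholin-4-yl or pyrrolidin-1-yl in place of diethylamino, or a longer chain such as 4-(diethylamino)butyl in place of 3-(diethylamino)propyl. Also open, from the compounds shown here alone, is how the two cores compare in this assay with the side chain held fixed, by numbers rather than limits.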